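Shortening the saturated chain in the series

This account rests on a few compounds, and the source may have more. Where it says the series, first, only, none or still open, it means among the compounds named here.

For the measured compounds named here, in a functional assay on CHO cells (Cricetulus griseus) for inhibition (on this read-out lower numbers stand for stronger inhibition and higher numbers for weaker inhibition), compound 1 (`CCCCCCCCCCCCCCC(=O)N[C@@H](CO)C[C@@H](O)c1ccccc1`) gives 90 nM and holds the only exact number so far. Compound 2 (`CCCCCCCCCCCCCCCCCC(=O)N[C@@H](CO)C[C@@H](O)c1ccccc1`) reads > 1000 nM as a limit of the assay and not as a number. Going by the values given here, the one measured step is an at least 11-fold higher number from compound 1 to compound 2 (1.04 log units; beyond the scatter) and it is large, with propyl in place of hydrogen on a saturated chain carbon, ten or more bonds along the chain from a carbonyl carbon.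

Compound 3 (`CCCCCCCCCCCCC(=O)N[C@@H](CO)C[C@@H](O)c1ccccc1`) runs the opposite way from compound 1, as hydrogen in place of ethyl on a saturated chain carbon, ten or more bonds along the chain from a carbonyl carbon and so carries the shorter chain. Among the compounds with values here, the measured step shows a weaker result on growing the chain, but no measured compound has a shorter one, so it fixes no direction here. Going by these compounds, with compound 1 at 90 nM as the only anchor, no change beyond the scatter is expected in this assay and either direction stays open. The estimate means a 1.1-fold lower number from compound 1 to compound 3 (0.05 log units; within the scatter) as the expected step. For compound 3 the estimated value is 80 nM with an expected range of 25 nM to 350 nM in repeat measurements.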

Compound 3, half-maximal inhibitory concentration: 50 nM
Beside the measured number, compound 3's estimate is 1.6-fold (0.20 log units) above it; low and high end bracket the measured number.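

In this assay, hydrogen in place of ethyl on a saturated chain carbon, ten or more bonds along the chain from a carbonyl carbon, gives a 1.8-fold lower number from compound 1 to compound 3 (0.26 log units; within the scatter), so the chains of these two compounds cannot be told apart on this read-out. For the compounds shown here, the sensitivity to chain length seen so far therefore appears on the lengthening side only, and hydrogen in place of pentyl at the same place gives an at least 20-fold lower number from compound 2 to compound 3 (1.30 log units; beyond the scatter), a step as large as the one from compound 1 to compound 2 or larger. The value of compound 2 is a limit of the assay and not a number: the limit of > 1000 nM in this assay, at which 1 of the 3 values shown sits.

Open, going by these compounds, is how a chain shorter than that of compound 3 would read, and whether a polar end on the chain, such as a terminal carboxylic acid or an amine, would be tolerated at this length. Also open, on these data alone, is how a chain of a length intermediate to those of compound 1 and compound 2 would read, so the point at which the read-out turns weaker stays unplaced.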